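Chloro Substitution on a Thymidylate Synthase Inhibitor Scaffold

This account rests on a few compounds, and the source may have more. Where it says the series, first, only, none or still open, it means among the compounds named here.

Compound 1 `Cc1ccc(-c2csc(=N)n2CC(=O)N2CCN(c3ccccc3)CC2)cc1`: 5600 nM
Compound 2 `N=c1scc(-c2ccccc2)n1CC(=O)N1CCN(c2ccccc2)CC1`: 1360 nM

In an assay on isolated protein for inhibition of Thymidylate synthase (Homo sapiens) (a lower number here means a stronger inhibitor, a higher number a weaker inhibitor), compound 2 gives 1360 nM, the lowest of the two numbers; compound 1 gives 5600 nM. Compound 3 `N=c1scc(-c2ccc(Cl)cc2)n1CC(=O)N1CCN(c2ccccc2)CC1` differs from compound 2 by chloro in place of hydrogen on an aromatic carbon. Going by the values given here, the only measured step that bears on this, a 4.1-fold lower number from compound 1 to compound 2 (0.61 log units; beyond the scatter), also swaps a group on an aromatic carbon, but a chloro entering is not a methyl leaving, so that step carries over only loosely. A step in this assay no larger than modest, in either direction, is expected, a 1.5-fold higher number from compound 2 to compound 3 (0.17 log units; within the scatter). Compound 3 is therefore estimated at 2000 nM, within 700 nM to 6000 nM.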

Compound 3, inhibition constant: 5090 nM
Compound 3: the middle estimate sits 2.5-fold (0.41 log units) below what was measured, and the stated range covers the measured number.
By their numbers in this assay, from the lowest: compound 2; then compounds 3 and 1 (each within the scatter of the next).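

In this assay, the change from phenyl to 4-chlorophenyl gives a 3.7-fold higher number from compound 2 to compound 3 (0.57 log units; beyond the scatter), so a second group at this place, para to a large group, also gives a higher number than hydrogen. Chloro and methyl here cannot be told apart, with a 1.1-fold lower number from compound 1 to compound 3 (0.04 log units; within the scatter). Nothing measured here explains why either group differs from hydrogen.

On these data alone, whether fluoro, an amine or a carboxylic acid at this place would match hydrogen or give a lower number remains open. So does whether any group here can improve on compound 2.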